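Softening the Acid Chain on a Weak Binder

The source may hold more compounds than are shown below. What is called first, only, known or untested is meant among the compounds shown, and "the series" means these compounds.

Of the compounds shown here, three have been measured in an assay on HEK293 cells for binding affinity to prostaglandin E2 receptor EP1 subtype (Homo sapiens); on this read-out higher numbers stand for weaker inhibition and lower numbers for stronger inhibition. Compound 1 `O=C(O)CCc1ccccc1-c1cc(-c2ccccc2OCc2ccccc2)cs1` gives 17500 nM in this assay. Compound 3 `O=C(O)CCc1ccccc1-c1ccc(-c2ccccc2OCc2ccccc2)s1` gives 27000 nM. Compound 2 `O=C(O)/C=C/c1ccccc1-c1cccc(-c2ccccc2OCc2ccccc2)c1` gives 72000 nM, the highest of the three numbers and so the weakest binding shown; its gaps to compound 3 and to compound 1 both lie beyond the usual scatter. Compound 4 `CC(Cc1ccccc1-c1cccc(-c2ccccc2OCc2ccccc2)c1)C(=O)O` has not yet been measured. It differs from compound 2 in one place: 2-carboxypropyl in place of 2-carboxyethenyl on an aromatic carbon. For the measured compounds named here, no measured pair differs in exactly this way, so there is no directly measured step to lean on, and compounds 1 and 3 carry a different core from compound 2, making them only a loose guide. Because compound 2 sits at 72000 nM with room below it, a modest move toward stronger binding is expected, a 2.1-fold lower number from compound 2 to compound 4 (0.31 log units; beyond the scatter), though a change within the scatter would not surprise. Compound 4 is estimated at 35000 nM, with a likely range from 10000 nM to 120000 nM.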

Compound 4, inhibition constant: 8300 nM
Compound 4: middle estimate off by 4.2-fold (0.62 log units), on the high side; measured number below the stated range.
By their numbers in this assay, from the lowest: compound 4; then compounds 1 and 3 (each within the scatter of the next); then compound 2.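

For the compounds shown here, replacing 2-carboxyethenyl with 2-carboxypropyl on an aromatic carbon, ortho to a large group, gives an 8.7-fold lower number from compound 2 to compound 4 (0.94 log units; beyond the scatter) in this assay, the first clear sign that the acid chain at this position can shift binding on its own, since no earlier pair differed in just one place. The swap makes two changes at once: the chain loses a double bond outside aromatic rings and gains a heavy atom, so this single step cannot divide the gain between them. Nothing measured here explains why binding improves.

As far as these compounds go, it remains open whether a longer chain at this position would bind better or worse than 2-carboxypropyl. From the compounds shown here alone, it is equally open whether a tetrazole could take the place of the carboxylic acid and keep this gain.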